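The source may hold more compounds than are shown below. What is called first, only, known or untested is meant among the compounds shown, and "the series" means these compounds.

Working notes on the series. In a functional assay on HepG2 cells (Homo sapiens) for inhibition, read by WST assay, with stated times of 72 h and 2 h (on this read-out higher numbers stand for weaker inhibition and lower numbers for stronger inhibition), compound 1 (`C#CCOC(c1cccs1)c1cc2ccccc2nc1Cl`) gives > 100000 nM, which is a limit of the assay and not a number. Compound 2 (`Clc1nc2ccccc2cc1C(OCc1ccccc1)c1cccs1`) is reported as "not active" (no number reported), so it has no number of its own. The only figure near it is the limit of > 100000 nM in this assay, at which 1 of the 2 values shown sits. Compound 3 (`FC(F)(F)c1cccc(COC(c2cccs2)c2cc3ccccc3nc2Cl)c1`) is the next to be read. The structural change is trifluoromethyl in place of hydrogen on an aromatic carbon, meta to a large group. For the measured compounds named here, no measured step shows what such a change does. With compound 2 at "not active" (no number reported), no step beyond the usual scatter is expected in this assay, and the reading is expected to stay weak. For compound 3 the estimated value is 100000 nM, with an expected range from 30000 nM to 200000 nM.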

Compound 3, half-maximal inhibitory concentration: "not active" (no number reported)
Compound 3: no number reported; the estimate stays without a comparison.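

Compound 2 and compound 3 are both reported as "not active" with no number, so no step can be read between them. The only figure nearby belongs to compound 1 and is a limit: the limit of > 100000 nM in this assay, at which 1 of the 3 values shown sits. As far as these compounds go, what trifluoromethyl in place of hydrogen does to the reading remains open.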